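A few compounds are considered here, and "the series" means these few. Any claim that something is new, unique, unknown or untested is made for them only; others in the source may bear on it.

Three related compounds have been tested in a functional assay on DU-145 cells (Homo sapiens) for cytotoxicity, read by MTT assay; a lower number here means a stronger inhibitor, a higher number a weaker inhibitor. Compound 1 `CC(C)=CC[C@@H](OC[C@@H](C)O)C1=CC(=O)c2c(O)ccc(O)c2C1=O` gives 14300 nM. Compound 2 `CC(C)=CC[C@@H](OCC(C)O)C1=CC(=O)c2c(O)ccc(O)c2C1=O` gives 16100 nM, and compound 3 `CC(=O)OC(C)CO[C@H](CC=C(C)C)C1=CC(=O)c2c(O)ccc(O)c2C1=O` gives 16600 nM; the steps of a 1.1-fold higher number from compound 1 to compound 2 (0.05 log units; within the scatter) and a 1.2-fold higher number from compound 1 to compound 3 (0.06 log units; within the scatter) both stay within the scatter, so compound 1 sits together with the other two rather than apart from them. The unmeasured compound 4 `CC(C)=CC[C@@H](OC(=O)C1CCCO1)C1=CC(=O)c2c(O)ccc(O)c2C1=O` differs from compound 1 in one place: (oxolan-2-yl)carbonyl in place of 2-hydroxypropyl on an oxygen on a saturated carbon. Among the compounds with values here, no measured step swaps the whole 2-hydroxypropyl for an ester; the nearest comparison is a 1.0-fold higher number from compound 2 to compound 3 (0.01 log units; within the scatter), where acetyl replaces hydrogen on an oxygen on a saturated carbon and nothing moves beyond the scatter. In this assay compound 4 is therefore expected to give 15000 nM, between 5000 nM and 45000 nM, an expected step of a 1.0-fold higher number from compound 1 to compound 4 (0.02 log units; within the scatter).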

Compound 4, half-maximal inhibitory concentration: 10500 nM
The estimate for compound 4 lay 1.4-fold (0.15 log units) above the measured number, within the range that was stated.
By their numbers in this assay, from the lowest: compounds 4, 1, 2 and 3 (each within the scatter of the next).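

Earlier compounds changed only the end of the side chain, whereas compound 4 replaces the whole 2-hydroxypropyl on this oxygen with (oxolan-2-yl)carbonyl, adding a five-membered ring and leaving no hydrogen-bond donor in the new group. Even so, every step in this assay stays within the scatter (a 1.4-fold lower number from compound 1 to compound 4 (0.13 log units; within the scatter)) (a 1.5-fold lower number from compound 2 to compound 4 (0.19 log units; within the scatter)) (a 1.6-fold lower number from compound 3 to compound 4 (0.20 log units; within the scatter)). This position therefore accepts a much larger change in these compounds without a clear shift in the number.

Nothing given here bears on the reason for this result. From the compounds shown here alone, whether an amine, a carboxylic acid or a longer chain at this oxygen would move the number remains open.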